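A few compounds are considered here, and "the series" means these few. Any claim that something is new, unique, unknown or untested is made for them only; others in the source may bear on it.

Compound 3, `c1ccc(-c2cnccn2)c(OCC2=NCCN2)c1`, carries a pyrazin-2-yl on the shared core. In a functional assay for activation of Alpha-1D adrenergic receptor (Homo sapiens), read by calcium flux (a higher number here means that more compound is needed for the effect, a lower number that less compound is needed), compound 3 gives < 100000 nM, which is a limit of the assay and not a number. Compound 2, `c1cnc(-c2ccccc2OCC2=NCCN2)nc1`, gives < 100000 nM in this assay, again a limit. Compound 1, `Cc1ccnc(-c2ccccc2OCC2=NCCN2)c1`, gives < 100000 nM in this assay, also a limit. All that is known is the limit of < 100000 nM in this assay, at which 3 of the 3 values shown sit. For the measured compounds named here, the one step that can be formed, a step that the two limits leave unreadable from compound 2 to compound 3, has no readable size. Compound 4, `c1coc(-c2ccccc2OCC2=NCCN2)c1`, differs from compound 3 by furan-2-yl in place of pyrazin-2-yl on an aromatic carbon. Going by the values given here, no measured step gives a size or direction for such a change, and the step that the limit leaves unreadable from compound 3 to compound 4 is therefore only an estimate. Compound 4 is expected in this assay at 30000 nM, in the range from 3000 nM to 100000 nM.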

Compound 4, half-maximal effective concentration: < 100000 nM
Compound 4: only a limit was reported; the forecaster's own chance of this, stated with the estimate: 70%; the middle value does not contradict the limit.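

For the compounds shown here, no step from compound 2 or compound 3 to compound 4 can be read, since each of these results is only a limit: the limit of < 100000 nM in this assay, at which 4 of the 4 values shown sit. The compounds shown leave open how much these groups on the shared core change the concentration needed in this assay.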